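Neutral carbamate side chains in a ceramide-like sphingomyelinase series

The compounds below may be only part of what the source reports. "The series", "measured", "known", "first", "only" and "open" are said of these compounds alone.

Measured so far in an assay on membranes from brain for inhibition of sphingomyelin phosphodiesterase 2 (Rattus norvegicus), using microsomes; a lower number here means a stronger inhibitor, a higher number a weaker inhibitor:
compound 1 `CCCCCCCCCCCCC/C=C/[C@@H](O)[C@H](COC(=O)NCCN(C)C)NC(=O)C(C)(C)C` gives 4100 nM.
compound 2 `CCCCCCCCCCCCC/C=C/[C@@H](O)[C@H](COC(=O)NCC[N+](C)(C)C)NC(=O)C(C)(C)C` gives 8700 nM.

For the measured compounds named here, compound 1 has the lowest number of the two; its only neighbour is compound 2, and the difference between them is a 2.1-fold higher number from compound 1 to compound 2 (0.33 log units; beyond the scatter).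

Compound 3 `CCCCCCCCCCCCC/C=C/[C@@H](O)[C@H](COC(=O)NCCC(C)(C)C)NC(=O)C(C)(C)C` differs from compound 1 by tert-butyl in place of dimethylamino on a saturated chain carbon, two bonds along the chain from an amide-type nitrogen. Going by the values given here, the single measured step, from compound 1 to compound 2, touches the same position but installs a charged group rather than removing the nitrogen, so it bears only loosely on the change to tert-butyl; it shows that altering this terminal group moves the number only modestly, toward a weaker inhibitor. On that basis no step beyond the scatter, or at most a modest rise, is expected for compound 3, as a 1.5-fold higher number from compound 1 to compound 3 (0.17 log units; within the scatter). Compound 3 is therefore estimated at 6000 nM, with a range of 2500 nM to 15000 nM in this assay.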

Compound 3, half-maximal inhibitory concentration: 77000 nM
Estimate against measurement, compound 3: 13-fold (1.11 log units) below; the measured number lies above the stated range.
By their numbers in this assay, from the lowest: compound 1; then compound 2; then compound 3.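

Swapping dimethylamino for tert-butyl, on a saturated chain carbon two bonds along the chain from an amide-type nitrogen, gives a 19-fold higher number from compound 1 to compound 3 (1.27 log units; beyond the scatter) in this assay, so this position is far less forgiving than the earlier step, a 2.1-fold higher number from compound 1 to compound 2 (0.33 log units; beyond the scatter), had suggested. The all-carbon group also falls well behind the charged group, with an 8.9-fold higher number from compound 2 to compound 3 (0.95 log units; beyond the scatter), so among these three compounds, both groups that contain nitrogen give lower numbers than tert-butyl, while the step between those two groups stays modest. No supporting data bear on why the nitrogen-free group gives the weakest inhibitor of the three.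

Still open, going by these compounds, is whether a primary amine or a morpholine would keep the number near that of compound 1. Also open, on these data alone, is whether a methoxy group, which keeps a heteroatom without a basic nitrogen, would behave like dimethylamino or like tert-butyl.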